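Trifluoromethyl in place of phenyl on compound 2

This account rests on a few compounds, and the source may have more. Where it says the series, first, only, none or still open, it means among the compounds named here.

In a functional assay on MCF7 cells (Homo sapiens) for inhibition, read by sulforhodamine B assay, with a stated time of 48 h, tested at 10 uM (on this read-out lower numbers stand for less inhibition of growth and higher numbers for more inhibition of growth at the one concentration tested), compound 1 (`CCOC(=O)c1ccc(Nc2ccnc(SCC(=O)c3ccc([N+](=O)[O-])cc3)n2)cc1`) gives 22% and compound 3 (`CC(=O)c1ccc(Nc2ccnc(SCC(=O)c3ccc(Cl)cc3)n2)cc1`) gives 19% while compound 2 (`CC(=O)c1cccc(Nc2ccnc(SCC(=O)c3ccc(-c4ccccc4)cc3)n2)c1`) gives 12% on the same scale. Compound 2 stands within the scatter of both other compounds, so no order among the three is drawn.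

Compound 4 (`CC(=O)c1cccc(Nc2ccnc(SCC(=O)c3ccc(C(F)(F)F)cc3)n2)c1`) derives from compound 2 with trifluoromethyl in place of phenyl on an aromatic carbon para to a large group. Among the compounds with values here, no two measured compounds differ in one place only, so the data give no direct size for this change. No step beyond the scatter is expected in this assay in either direction. That expectation rests only on compound 2 at 12% and compound 1 at 22% lying within the scatter of each other despite their differing substituents. The estimate amounts to a number 3 percentage points higher from compound 2 to compound 4 (within the scatter) as the expected step. Compound 4 is estimated at 15% with an expected range from 3% to 30% on this read-out.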

Compound 4, percent growth inhibition at one concentration: 26%
The estimate for compound 4 lay 11 percentage points below the measured number, and the stated range covers the measured number.
By their numbers in this assay, from the lowest: compounds 2, 3, 1 and 4 (each within the scatter of the next, the first and the last beyond it).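

Within the data shown here, the change from phenyl to trifluoromethyl on an aromatic carbon, para to a large group, gives a number 14 percentage points higher from compound 2 to compound 4 (beyond the scatter) in this assay and is the first step that can be read at a single place. This position is therefore not silent on this read-out, and of this pair the compound carrying the group with no ring has the higher number, although the step is modest and rests on one pair only. No measured evidence on hand bears on the reason for this step.

Going by these compounds, whether the step belongs to trifluoromethyl itself or to the loss of phenyl stays open, and a methoxy group or an amine at this place on compound 2 would help separate the two. On these data alone, compound 1 and compound 3 differ from compound 4 in more than one place, so whether the step holds on their substitution patterns also stays open.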